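Methylphenyl isomer on the ring nitrogen: compound 4

A few compounds are considered here, and "the series" means these few. Any claim that something is new, unique, unknown or untested is made for them only; others in the source may bear on it.

Compound 1 `CCCC(Oc1cnn(-c2cccc(C)c2)c1)c1ccc(C(=O)NCCC(=O)O)cc1` was tested in a functional assay on cells for antagonist activity at Glucagon receptor (Homo sapiens), read by cAMP accumulation; a lower number here means a stronger inhibitor, a higher number a weaker inhibitor. For compound 1 this assay reports only the limit > 20900 nM, not a number, so compound 1 stands at the limit of > 20900 nM in this assay, at which 1 of the 3 values shown sits, and its true value is open on one side. The chloro counterpart, compound 2 `CCCC(Oc1cnn(-c2cccc(Cl)c2)c1)c1ccc(C(=O)NCCC(=O)O)cc1`, gives 16900 nM in this assay. The step of an at least 1.2-fold lower number from compound 1 to compound 2 (0.09 log units; that floor lies within the scatter) is thus bounded from one side only, and its floor lies within the scatter. Among the measured compounds shown here, compound 3 `CCCc1c(C(C)C)cc(C(C)C)c(C(C)O)c1-c1ccc(F)cc1`, of a different build, gives 78 nM in this assay; no single-point step joins it to compound 1, so its value shows only that this assay returns low numbers for other chemotypes.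

Compound 4 `CCCC(Oc1cnn(-c2ccccc2C)c1)c1ccc(C(=O)NCCC(=O)O)cc1` differs from compound 1 by 2-methylphenyl in place of 3-methylphenyl on an aromatic nitrogen. For the measured compounds named here, the one measured step at this ring, an at least 1.2-fold lower number from compound 1 to compound 2 (0.09 log units; that floor lies within the scatter), exchanges the substituent itself and stays within the scatter at its floor; for the exchange of one methylphenyl for another no measured step exists. Compound 4 is therefore expected near the limit, at 22000 nM in this assay, with a range from 8000 nM to 60000 nM. The expected step that the limit leaves unreadable from compound 1 to compound 4 lies within the scatter, and this assay may well again report only a limit for compound 4.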

Compound 4, antagonist equilibrium constant: > 23600 nM
Compound 4: only a limit was reported (the forecaster's own chance of this, stated with the estimate: 55%); middle value at least 1.0-fold (0.03 log units) away from the limit.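

In this assay compound 4 gives > 23600 nM, which is a limit and not a number, so 2-methylphenyl on the aromatic nitrogen joins 3-methylphenyl in returning no measurable value at this position. The step between these two methylphenyl isomers cannot be read, as both ends are limits, and the series gives no sign yet of whether this change of methyl placement matters at all. Among the compounds shown here, the one readable comparison, an at least 1.3-fold higher number from compound 2 to compound 4 (0.14 log units; that floor lies within the scatter), is bounded from one side only and its floor lies within the scatter, so 2-methylphenyl is not separated from 3-chlorophenyl on these figures.

From the compounds shown here alone, whether an unsubstituted phenyl, or a phenyl carrying methoxy or trifluoromethyl, on the aromatic nitrogen would give a number in place of a limit stays open. Also open, going by these compounds, is whether a change elsewhere on the shared core, such as a longer chain in place of the propyl chain, would bring this series closer to the low values that this assay can return.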